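The source may hold more compounds than are shown below. What is called first, only, known or untested is meant among the compounds shown, and "the series" means these compounds.

Working notes on the series.

Three compounds share one core and are measured in an assay on isolated protein for inhibition of thyroid hormone receptor beta (Homo sapiens), read by fluorescence, with a stated time of 30 min; a higher number here means a weaker inhibitor, a lower number a stronger inhibitor. Compound 1 `COc1cc(C(=O)N2CCC(O)C(C)C2)cc2nc(NCc3cccc(Cl)c3)oc12` gives 25 nM. Compound 2 `COc1cc(C(=O)N2CCC(O)C(C)C2)cc2nc(NCc3ccnc(Cl)c3)oc12` gives 6900 nM, and the step of a 280-fold higher number from compound 1 to compound 2 (2.44 log units; beyond the scatter) is the largest in the set. Compound 3 `COc1cc(C(=O)N2CCC(O)C(C)C2)cc2nc(N[C@H](C)c3cccc(Cl)c3)oc12` gives 48 nM, which places it second highest of the three numbers; its nearest neighbour is compound 1, as the step of a 1.9-fold higher number from compound 1 to compound 3 (0.28 log units; within the scatter) shows, and its furthest is compound 2, with the step of a 140-fold lower number from compound 2 to compound 3 (2.16 log units; beyond the scatter).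

The next compound, compound 4 `COc1cc(C(=O)N2CCC(O)C(C)C2)cc2nc(NC3(c4cccc(Cl)c4)CCC3)oc12`, differs from compound 3 in one place: 1-(3-chlorophenyl)cyclobutyl in place of 1-(3-chlorophenyl)ethyl on a nitrogen on an aromatic ring. For the measured compounds named here, no measured step covers the same change. Going by the values given here, the only step that bears on it is a 1.9-fold higher number from compound 1 to compound 3 (0.28 log units; within the scatter), which shows that a methyl on the saturated chain carbon bound to the aromatic carbon and the nitrogen leaves this assay unchanged within the scatter. Compound 4 closes that carbon into a four-membered ring, a larger change than any measured one at this site, so the size of the step is uncertain; a modest move toward a higher number is expected, a 1.9-fold higher number from compound 3 to compound 4 (0.27 log units; within the scatter), though a result within the scatter would not surprise. Compound 4 is therefore estimated at 90 nM, with a range from 20 nM to 450 nM.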

Compound 4, half-maximal inhibitory concentration: 8200 nM
The estimate for compound 4 lay 91-fold (1.96 log units) below the measured number; measured number above the stated range.
By their numbers in this assay, from the lowest: compounds 1 and 3 (each within the scatter of the next); then compounds 2 and 4 (each within the scatter of the next).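

On a nitrogen on an aromatic ring, the tolerance for a single methyl does not extend to 1-(3-chlorophenyl)cyclobutyl: in this assay this change gives a large step (a 170-fold higher number from compound 3 to compound 4 (2.23 log units; beyond the scatter)), and the step from the unbranched 3-chlorobenzyl group is also large (a 330-fold higher number from compound 1 to compound 4 (2.52 log units; beyond the scatter)). The chain carbon that accepts the methyl of compound 3 therefore does not accept the closed ring of compound 4, so this position is sharply limited in what it takes, and the change from 9 to 11 heavy atoms is enough to lose almost all of the activity seen with compounds 1 and 3. That loss matches the one seen on moving to 2-chloropyridin-4-yl, since the step between the two weak compounds lies within the scatter (a 1.2-fold higher number from compound 2 to compound 4 (0.07 log units; within the scatter)), and nothing on hand explains either loss.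

The compounds shown leave open whether the closed ring itself or the second substituent on that carbon drives the loss, a question that a gem-dimethyl group or a cyclopropyl ring at this carbon would address. They also leave open how the other enantiomer of the 1-(3-chlorophenyl)ethyl group of compound 3 would behave.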